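Removing the methoxy from the core of compound 1

This account rests on a few compounds, and the source may have more. Where it says the series, first, only, none or still open, it means among the compounds named here.

The three measured compounds share one core and differ only in a group on the other aromatic ring. Compound 1 `COc1ccc(-c2cc(OC)cc(C(=O)Nc3nn[nH]n3)n2)cc1` gives 25% in a functional assay on the whole organism for inhibition, with Rattus norvegicus as the target, at a dose of 1 mg/kg by the oral route; a higher number here means a stronger effect of the compound at the dose given, a lower number a weaker effect. Compound 2 `COc1cc(C(=O)Nc2nn[nH]n2)nc(-c2ccc(C(C)(C)C)cc2)c1` gives 29% and compound 3 `CNc1ccc(-c2cc(OC)cc(C(=O)Nc3nn[nH]n3)n2)cc1` gives 35%. Compound 1 holds the lowest of the three numbers, yet the step of a number 4 percentage points higher from compound 1 to compound 2 (within the scatter) and the step of a number 10 percentage points higher from compound 1 to compound 3 (within the scatter) both lie within the scatter, as does a number 6 percentage points higher from compound 2 to compound 3 (within the scatter), so the three numbers cannot be set in any order.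

Compound 4 `COc1ccc(-c2cccc(C(=O)Nc3nn[nH]n3)n2)cc1` differs from compound 1 in a different place: hydrogen in place of methoxy on an aromatic carbon. Among the measured compounds shown here, none of the measured steps bears on this change; each concerns the methoxy, tert-butyl or methylamino group, not the core, and each was small. The data give no direct guide to the size or direction of the step, and the most that can be said is that every change seen so far has left this assay unmoved beyond the scatter. Close to the number of compound 1, compound 4 is expected to give an estimated 22% with a range from 5% to 45%. The step of a number 3 percentage points lower from compound 1 to compound 4 (within the scatter) is thus expected to remain within the scatter.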

Compound 4, a percentage reported as inhibition, in the whole organism at one dose (the size of the read-out at that dose, not a potency): 12%
For compound 4 the middle estimate is 10 percentage points above the measured one, within the range that was stated.
By their numbers in this assay, from the lowest: compound 4; then compounds 1, 2 and 3 (each within the scatter of the next).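

With the methoxy replaced by hydrogen on the aromatic carbon opposite the ring nitrogen, the number in this assay moves a number 13 percentage points lower from compound 1 to compound 4 (beyond the scatter), the first step shown that passes the scatter. The earlier steps shown here all concerned the group on the other aromatic ring, and none of them could be read, whereas this single change to the shared core can be read, and the number is lower without the methoxy than with it. That is one comparison at one position in one assay at a single dose, and nothing shown accounts for the drop.

The compounds shown leave open whether the methoxy itself matters at this position or whether another group there, such as an ethoxy group, an amine or a fluorine atom, would give a number like that of compound 1 or a different one. They also leave open whether removing the methoxy lowers the number to a similar extent when tert-butyl or methylamino stands on the other aromatic ring in place of the methoxy of compound 4.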